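This account rests on a few compounds, and the source may have more. Where it says the series, first, only, none or still open, it means among the compounds named here.

Measured compounds:
compound 1: `Cc1ccc2c(c1NS(C)(=O)=O)CCC2c1ncc[nH]1`, > 10000 nM
compound 2: `Cn1cc(-c2cccc3c2CCC3c2ncc[nH]2)cn1`, > 10000 nM

In a functional assay on CHO cells for agonist activity at Alpha-1B adrenergic receptor (Homo sapiens), read by FLIPR and calcium flux (a lower number here means that less compound is needed, a higher number that more compound is needed for the effect), compound 1 gives > 10000 nM, which is a limit of the assay rather than a number. Compound 2 gives > 10000 nM in this assay, again a limit and not a number. Compound 2 thus stands at the limit of > 10000 nM in this assay, at which 2 of the 2 values shown sit, and compound 1 stands there as well, so the two values say no more than that both lie beyond the reach of the measurement. Compound 3, `c1cc(-c2ccn[nH]2)c2c(c1)C(c1ncc[nH]1)CC2`, has not been measured yet. It differs from compound 2 by a single change: 1H-pyrazol-5-yl in place of 1-methyl-1H-pyrazol-4-yl on an aromatic carbon. Within the data shown here, with compound 2 showing only a limit, there is no measured step to lean on. The step from compound 2 to compound 3 in this assay is estimated as a step that the limit leaves unreadable from compound 2 to compound 3, none beyond the scatter. Compound 3 is therefore expected to give about 15000 nM in this assay, between 3000 nM and 60000 nM, most likely again reported only as a limit.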

Compound 3, half-maximal effective concentration: 600 nM
Beside the measured number, compound 3's estimate is 25-fold (1.40 log units) above it; the whole stated range lies above it.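

In this assay, 1H-pyrazol-5-yl in place of 1-methyl-1H-pyrazol-4-yl on this aromatic carbon gives an at least 16-fold lower number from compound 2 to compound 3 (1.22 log units; beyond the scatter), so the group held at this position can decide whether a measurable agonist effect appears at all. Compound 3 is the first of the compounds shown to give a number rather than a limit. Compound 2 gives only a limit, so the step has a lower bound but no exact size: the limit of > 10000 nM in this assay, at which 2 of the 3 values shown sit.

The change alters the methyl group, the point of attachment of the ring and the count of hydrogen-bond donors all at once, and the compounds shown do not separate these. Also open, going by these compounds, is how another group on this carbon, such as an amine, a carboxylic acid or a longer chain, would read in this assay.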